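This account rests on a few compounds, and the source may have more. Where it says the series, first, only, none or still open, it means among the compounds named here.

Working notes on the series. In a functional assay on HUVEC cells (Homo sapiens), read by BrdU incorporation, with a stated time of 72 h (a higher number here means a weaker inhibitor, a lower number a stronger inhibitor), compound 1 (`Cc1ccc2nc(Cl)c(/C=C/C(=O)c3sccc3C)cc2c1`) reads (127 nM), compound 2 (`Cc1ccc2cc(/C=C/C(=O)c3ccc(Br)s3)c(Cl)nc2c1`) reads (83.6 nM) and compound 3 (`Cc1cccc2cc(/C=C/C(=O)c3ccc(Br)s3)c(Cl)nc12`) reads (243 nM). Compound 1 stands in the middle of these three numbers, and its gaps to compound 2 and to compound 3 both lie within the scatter.

The next compound to read is compound 4 (`Cc1ccc2nc(Cl)c(/C=C/C(=O)c3cc(Cl)sc3Cl)cc2c1`), which keeps the core of compound 1. The change is 2,5-dichlorothiophen-3-yl in place of 3-methylthiophen-2-yl on a carbonyl carbon. For the measured compounds named here, no two measured compounds differ in one place only, so no measured step speaks directly to this change, and the direction of any shift cannot be argued from the data.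

Going by the values given here, the only guide is the range of the series, with compound 2 at (83.6 nM) and compound 3 at (243 nM) on either side of compound 1. On that basis, no step beyond the scatter is expected in this assay for this change. The expected step is small (a 1.2-fold higher number from compound 1 to compound 4 (0.07 log units; within the scatter)) and stays within the scatter. For compound 4 the estimated value is 150 nM (expected range 60 nM to 380 nM) in this assay.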

Compound 4, half-maximal inhibitory concentration: 26.2 nM
The estimate for compound 4 lay 5.7-fold (0.76 log units) above the measured number; measured number below the stated range.
By their numbers in this assay, from the lowest: compound 4; then compounds 2, 1 and 3 (each within the scatter of the next, the first and the last beyond it).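

In this assay, for the compounds shown here, the group on a carbonyl carbon is the first place where a change in one place can be read, and it is not a silent one: 2,5-dichlorothiophen-3-yl in place of 3-methylthiophen-2-yl gives a 4.8-fold lower number from compound 1 to compound 4 (0.69 log units; beyond the scatter) with the core of compound 1 kept. The step comes with a single added heavy atom, while the counts of hydrogen-bond donors and acceptors stay the same, the net charge stays absent and the five-membered aromatic ring with its one hetero atom remains, so a large part of the sensitivity here rests on the substitution and attachment of that ring rather than on its type. Nothing on hand gives a reason for this step.

The change alters the substituents and the point of attachment of the ring in one move, so the compounds shown cannot assign the step to the chlorine atoms, to the loss of the methyl group or to the attachment. Also open, from the compounds shown here alone, is how this place answers to a quite different group on the thiophene, such as an amine or a carboxylic acid, and whether the step carries over to other cores.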